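A few compounds are considered here, and "the series" means these few. Any claim that something is new, unique, unknown or untested is made for them only; others in the source may bear on it.

Among the measured compounds shown here, compound 1 `CC(=O)N1CCN(CCN2CCC(CNC(=O)c3cccc4[nH]c(C(C)C)nc34)CC2)CC1` is the stronger of the two compounds measured so far in a functional assay for agonist activity at 5-hydroxytryptamine receptor 4 (Homo sapiens), read by cAMP accumulation (on this read-out lower numbers stand for smaller maximal responses and higher numbers for larger maximal responses), where compound 1 gives 76%. For the measured compounds named here, the only other measured compound, compound 2 `CS(=O)(=O)N1CCN(CC(O)CN2CCC(CNC(=O)c3cccc4[nH]cnc34)CC2)CC1`, gives in this assay 6%, a number that lies far below that of compound 1, well beyond the usual scatter of this kind of measurement; no single-point step links these two compounds, so nothing more than this gap can be read from them.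

Compound 3 `COC(=O)N(C)CC(O)CN1CCC(CNC(=O)c2cccc3[nH]c(C(C)C)nc23)CC1` has not yet been measured in this assay. It departs from compound 1 by one change: 1-hydroxy-2-((methoxycarbonyl)(methyl)amino)ethyl in place of (4-acetylpiperazin-1-yl)methyl on a saturated chain carbon bound to an amine nitrogen in a ring.

Because compound 2, which also carries a hydroxylated open chain in place of a ring-linked group, gives 6%, a step downward from compound 1 is expected, of a size beyond the scatter, though a less steep one, since compound 3 keeps more of the shape of compound 1 than compound 2 does. Compound 3 is therefore estimated to reach about 45% in this assay, within a range from 15% to 78%, a step of a number 31 percentage points lower from compound 1 to compound 3 (beyond the scatter) expected from compound 1.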

Compound 3, intrinsic activity: the largest response reached, in percent of the reference agonist's: 64%
Beside the measured number, compound 3's estimate is 19 percentage points below it; the range from low to high includes it.
By their numbers in this assay, from the lowest: compound 2; then compound 3; then compound 1.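

Among the compounds shown here, the step of a number 12 percentage points lower from compound 1 to compound 3 (beyond the scatter) is the first single-change reading at this place, on a saturated chain carbon bound to an amine nitrogen in a ring, in this assay. It shows that a high maximal response does not depend on the (4-acetylpiperazin-1-yl)methyl group: compound 3, whose open 1-hydroxy-2-((methoxycarbonyl)(methyl)amino)ethyl group has no ring and carries one hydrogen-bond donor where the group of compound 1 has none, loses only a modest part of that response, though the loss lies beyond the usual scatter. No other measurement bears on why the response falls by this amount.

The change replaces the ring, adds the hydroxyl and brings in the methoxycarbonyl group all at once, so this single step cannot divide its size among them, and compound 2 differs from both other compounds in more than one place, so its low number cannot be tied to this position. As far as these compounds go, it also remains open whether a shorter chain ending in a dimethylamino group or a carboxylic acid would keep the response at this place.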